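The source may report more compounds than this note shows. Statements on the series, on what has been measured and on what is new or still open speak of the compounds shown alone.

In an ADME assay on HeLa cells (Homo sapiens) for cytotoxicity, read by resazurin assay, with a stated time of 65 h (a lower number here means that less compound is needed, a higher number that more compound is needed for the effect), compound 1 `CCCCc1cc(C(=O)OCC)c(NC(=O)c2ccc([N+](=O)[O-])o2)s1` gives > 20000 nM as a limit of the assay and not as a number. Compound 2 `CCc1cc(C(N)=O)c(NC(=O)c2cccc([N+](=O)[O-])c2)s1` gives > 20000 nM which is likewise a limit. As far as these compounds go, compound 3 `O=C(Nc1ccc(C(F)(F)F)cc1)c1ccc([N+](=O)[O-])o1` gives > 20000 nM and that too is only a limit, so its exact place on the scale remains unknown. All three readings are the same kind of result, namely the limit of > 20000 nM in this assay, at which 3 of the 3 values shown sit, and none of them offers an exact figure to build on.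

Compound 4 `C=CCOc1ccc(NC(=O)c2ccc([N+](=O)[O-])o2)cc1` differs from compound 3 in one place, with allyloxy in place of trifluoromethyl on an aromatic carbon, para to a large group (allyloxy in place of trifluoromethyl on an aromatic carbon). Within the data shown here, no two measured compounds differ in just one place, so no measured step gives the size of this change. The expectation in this assay therefore rests on compound 3 with its limit of > 20000 nM and on the lack of any exact number among the three tested compounds. The expected step of a number no higher from compound 3 to compound 4 (the limit leaves the size open) is small and stays within the usual scatter, with no direction favoured. For compound 4 the estimated value is 20000 nM with an expected range from 8000 nM to 50000 nM and a limit may well be expected once more.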

Compound 4, half-maximal effective concentration: > 20000 nM
Compound 4 ended at the assay's limit (the forecaster's own chance of this, stated with the estimate: 70%); the middle value lies on the limit itself.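

Compound 3 and compound 4 both end at a limit of the assay rather than at a number, so swapping trifluoromethyl for allyloxy gives no step that can be read: the limit of > 20000 nM in this assay, at which 4 of the 4 values shown sit.

The compounds shown leave open how far each one lies beyond that limit, and whether a change in one place shifts the reading at all.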